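Fluoro in place of hydrogen on compound 3

The source may report more compounds than this note shows. Statements on the series, on what has been measured and on what is new or still open speak of the compounds shown alone.

The three measured compounds share one core. Compound 1 `O=C(Nc1ccc(Oc2ccnc3[nH]ccc23)cc1)c1cc(-c2ccc(Cl)cc2)ncn1`, compound 2 `O=C(Nc1ccc(Oc2ccnc3[nH]ccc23)cc1)c1cc(-c2ccc(C(F)(F)F)cc2)ncn1` and compound 3 `Cc1ccc(-c2cc(C(=O)Nc3ccc(Oc4ccnc5[nH]ccc45)cc3)ncn2)cc1` differ only in the group carried on an aromatic carbon: chloro, trifluoromethyl and methyl. In a functional assay on MCF7 cells (Homo sapiens) for cytotoxicity, read by MTT assay, with a stated time of 72 h (a higher number here means a weaker inhibitor, a lower number a stronger inhibitor), compound 1 gives 7770 nM, compound 2 gives 6240 nM and compound 3 gives 1620 nM. Compound 3 has the lowest number of the three, since a 4.8-fold lower number from compound 1 to compound 3 (0.68 log units; beyond the scatter) and a 3.9-fold lower number from compound 2 to compound 3 (0.59 log units; beyond the scatter) both lie beyond the scatter, whereas a 1.2-fold lower number from compound 1 to compound 2 (0.10 log units; within the scatter) does not.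

Compound 4 `Cc1ccc(-c2cc(C(=O)Nc3ccc(Oc4ccnc5[nH]ccc45)c(F)c3)ncn2)cc1` keeps the methyl of compound 3 and differs from it only by fluoro in place of hydrogen on an aromatic carbon. None of the three measured steps bears on this change: each of them exchanges one group for another on an aromatic carbon, and none replaces a hydrogen by fluoro anywhere in the core. The measured steps therefore give no direction for this change. Without a measured step to go by, the expectation for compound 4 in this assay is a number close to that of compound 3, a step of a 1.0-fold lower number from compound 3 to compound 4 (0.01 log units; within the scatter) that is not expected to exceed the scatter. The estimate for compound 4 is 1600 nM, with a range from 600 nM to 4500 nM.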

Compound 4, half-maximal inhibitory concentration: 6730 nM
For compound 4 the middle estimate is 4.2-fold (0.62 log units) below the measured one, and the stated range ends below it.
By their numbers in this assay, from the lowest: compound 3; then compounds 2, 4 and 1 (each within the scatter of the next).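

In this assay, fluoro in place of hydrogen on an aromatic carbon of the six-membered aromatic ring of carbon only, ortho to a large group and meta to a large group, is not a silent change: the step is a 4.2-fold higher number from compound 3 to compound 4 (0.62 log units; beyond the scatter). The earlier compounds shown here varied only the group on a different aromatic carbon, and this single added fluorine atom moves the number in the opposite direction and by a size of the same order as a 4.8-fold lower number from compound 1 to compound 3 (0.68 log units; beyond the scatter) and a 3.9-fold lower number from compound 2 to compound 3 (0.59 log units; beyond the scatter), so the number in this assay also responds to a change at this second place in the core. Nothing at hand gives a reason for this step.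

The compounds shown leave open whether the higher number belongs to fluoro itself or would also follow from a different group at this place, such as a methoxy group or an amine. They also leave open whether fluoro at this place gives a step of similar size when chloro or trifluoromethyl replaces the methyl.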